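Replacing the Phenol Arm of Compound 2

The source may hold more compounds than are shown below. What is called first, only, known or untested is meant among the compounds shown, and "the series" means these compounds.

In an assay on CHO cells for inhibition of Glucagon receptor (Homo sapiens), tested at 20 uM (on this read-out higher numbers stand for more inhibition at the one concentration tested (going by the name of the read-out) and lower numbers for less inhibition), compound 1 `CCC/C=C/c1c(C(C)C)nc(C(C)C)c(CO)c1-c1ccc(S(C)(=O)=O)cc1` gives 14%. For the measured compounds named here, compound 2 `CCCCCc1c(C(C)C)nc(C(C)C)c(CO)c1-c1ccc(O)cc1` gives 24% in this assay, a number that lies within the usual scatter of the one from compound 1, so neither stands apart from the other. Compound 3 `CCCCCc1c(C(C)C)nc(C(C)C)c(CO)c1-c1ccccc1CO` has not yet been measured in this assay; it differs from compound 2 by 2-(hydroxymethyl)phenyl in place of 4-hydroxyphenyl on an aromatic carbon. No measured step of this kind exists among these compounds, so the expected change a number 4 percentage points lower from compound 2 to compound 3 (within the scatter) is none beyond the scatter, in either direction. Compound 3 is accordingly estimated to give 20% in this assay, within a range from 3% to 42%.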

Compound 3, a percentage reported as inhibition, at one concentration (the size of the read-out at that concentration, not a potency): 44%
The estimate for compound 3 lay 24 percentage points below the measured number; measured number above the stated range.
By their numbers in this assay, from the lowest: compounds 1 and 2 (each within the scatter of the next); then compound 3.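

In this assay, 2-(hydroxymethyl)phenyl in place of 4-hydroxyphenyl on this aromatic carbon, opposite the ring nitrogen, gives a number 20 percentage points higher from compound 2 to compound 3 (beyond the scatter). The number at this position therefore moves beyond the scatter with the aryl group alone changed and the pentyl group kept, although the step is modest. Nothing shown accounts for the step. The compounds shown leave open whether the hydroxyl oxygen matters, and how an aminomethyl group or a carboxylic acid would compare with the hydroxymethyl group on that phenyl ring.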